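A few compounds are considered here, and "the series" means these few. Any claim that something is new, unique, unknown or untested is made for them only; others in the source may bear on it.

In a functional assay on RAW264.7 cells (Mus musculus) for inhibition, read by Griess assay, with stated times of 2 h and 18 h (a lower number here means a stronger inhibitor, a higher number a weaker inhibitor), compound 1 `CCOC1CC(O)(CCC2=C(C)C(=O)[C@@H](O)[C@H]3C(C)(C)[C@H](OC(C)=O)CC[C@]23C)CO1` gives 30400 nM, compound 2 `CCC(=O)[C@H]1O[C@@](CCC2=CC(OC)OC2=O)(OC)[C@@]2(C)CCCC(C)(C)[C@H]12` gives 3900 nM, and compound 3 `CCC(=O)[C@H]1O[C@](O)(CCC2=CC(OC)OC2=O)[C@@]2(C)CCCC(C)(C)[C@H]12` gives 15700 nM. Compound 3 thus sits within the scatter of compound 1 and clearly above compound 2. Compound 4 `CCC(=O)[C@H]1O[C@](O)(CCc2ccoc2)[C@@]2(C)CCCC(C)(C)[C@H]12` carries furan-3-yl on the chain in place of the group found in compound 3: a group of 5 heavy atoms (4 carbon, 1 oxygen; one five-membered aromatic ring with 1 hetero atom) in place of a group of 8 heavy atoms (5 carbon, 3 oxygen; one five-membered non-aromatic ring with 1 hetero atom), on a saturated chain carbon, two bonds along the chain from a saturated ring carbon. Among the compounds with values here, the one measured step, a 4.0-fold higher number from compound 2 to compound 3 (0.60 log units; beyond the scatter), is modest and concerns a hydrogen in place of methyl on an oxygen, so it bears only indirectly on this replacement. Within the data shown here, no measured step exchanges this group, and the data give no direction. In this assay, the expected result is therefore a 1.1-fold lower number from compound 3 to compound 4 (0.05 log units; within the scatter), with nothing beyond the scatter anticipated. For compound 4 the estimate is 14000 nM, with an expected range of 4000 nM to 45000 nM.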

Compound 4, half-maximal inhibitory concentration: > 50000 nM
Compound 4: only a limit was reported (the forecaster's own chance of this, stated with the estimate: 15%); at least 3.5-fold (0.55 log units) between middle value and limit.
By their numbers in this assay, from the lowest: compound 2; then compounds 3 and 1 (each within the scatter of the next). At a limit, above all of these: compound 4.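

Compound 4 is reported only as a limit, so its number gives a minimum and not a measured size: the limit of > 50000 nM in this assay, at which 1 of the 4 values shown sits. At the saturated chain carbon, furan-3-yl in place of the five-membered non-aromatic ring of compound 3 gives an at least 3.1-fold higher number from compound 3 to compound 4 (0.50 log units; beyond the scatter) in this assay. This shows that the chain-end group itself matters to the read-out, which the earlier step on the oxygen methyl could not show. The compounds shown leave open how large the true step is. They also leave open whether a phenyl ring or an open-chain ester at this place would keep the number of compound 3.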